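The compounds below may be only part of what the source reports. "The series", "measured", "known", "first", "only" and "open" are said of these compounds alone.

Compound 1 `COc1ccc(C2=NN(C(=O)c3cccnc3)C(c3cn(C)c4ccc(Br)cc34)C2)cc1`: 1190 nM
Compound 2 `COc1ccc(C2=NN(C(=O)c3cccnc3)C(c3cn(C)c4ccc(Br)cc34)C2)cc1OC`: 2380 nM
Compound 3 `COc1ccc2c(c1)c(C1CC(c3ccccc3)=NN1C(=O)c1cccnc1)cn2C`: reported only as a limit, > 10000 nM

All three were tested in a functional assay on A549 cells (Homo sapiens) for inhibition, read by MTT assay, with a stated time of 48 h; a lower number here means a stronger inhibitor of growth, a higher number a weaker inhibitor of growth. Compound 1 and compound 2 share a core and differ by methoxy in place of hydrogen on an aromatic carbon; this change gives a 2.0-fold higher number from compound 1 to compound 2 (0.30 log units; within the scatter). Compound 3 sits at the limit of > 10000 nM in this assay, at which 1 of the 3 values shown sits, so only a limit is known for it. The difference between the core of compound 3 and the core of compound 1 is not broken down here.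

Compound 4 `COc1cccc(C2=NN(C(=O)c3cccnc3)C(c3cn(C)c4ccc(OC)cc34)C2)c1` has not yet been measured. It differs from compound 3 by methoxy in place of hydrogen on an aromatic carbon. Within the data shown here, this is the same kind of change as the one from compound 1 to compound 2, though not the same: in compound 2 the entering methoxy is also ortho to a methoxy group, whereas in compound 4 it is not. The earlier step of a 2.0-fold higher number from compound 1 to compound 2 (0.30 log units; within the scatter) lay within the scatter, and compound 3 gives only a limit, so compound 4 is expected to remain near that limit. For compound 4 the expected step is a step that the limit leaves unreadable from compound 3 to compound 4, which rests on the size of a 2.0-fold higher number from compound 1 to compound 2 (0.30 log units; within the scatter). Compound 4 is estimated at 15000 nM, most likely between 5000 nM and 50000 nM, with a good chance that only a limit is again reported.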

Compound 4, concentration for 50% growth inhibition: 1020 nM
Compound 4: middle estimate off by 15-fold (1.17 log units), on the high side; the measured number lies below the stated range.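

In this assay, turning phenyl into 3-methoxyphenyl gives an at least 9.8-fold lower number from compound 3 to compound 4 (0.99 log units; beyond the scatter). The same kind of change therefore does not carry over in size from one core to the other, and a step seen on one core is a poor guide to the step on another in this series: the same change on two cores in this assay, a 2.0-fold higher number (0.30 log units; within the scatter) from compound 1 to compound 2 and an at least 9.8-fold lower number (0.99 log units; beyond the scatter) from compound 3 to compound 4, at least 19-fold (1.29 log units) apart, beyond the scatter of two such steps

Compound 3 is reported only as a limit, > 10000 nM, and these two steps show neither the full size of the second step nor why the two differ.

The compounds shown leave open whether the stronger growth inhibition of compound 4 depends on where the methoxy sits on the phenyl ring, as this core shows it in one place only. From the compounds shown here alone, it is also open whether another group in that place, such as a hydroxyl, an amine or a fluorine atom, would lower the number in the same way.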